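Shrinking the aryl ether of compound 1: an expectation

The source may hold more compounds than are shown below. What is called first, only, known or untested is meant among the compounds shown, and "the series" means these compounds.

Measured so far in a functional assay on MCF7 cells (Homo sapiens) for cytotoxicity, read by MTT assay, with a stated time of 72 h; on this read-out lower numbers stand for stronger inhibition and higher numbers for weaker inhibition:
compound 1, `COc1ccc(/C=N/NC(=O)Nc2cc3c(Nc4ccc(F)c(Cl)c4)ncnc3cc2O[C@H]2CCOC2)c(OC)c1OC`, gives 33800 nM
compound 2, `O=C(N/N=C/c1ccc(O)cc1)Nc1cc2c(Nc3ccc(F)c(Cl)c3)ncnc2cc1O[C@H]1CCOC1`, gives 910 nM

Within the data shown here, compound 1 stands highest of the two numbers; its nearest neighbour is compound 2, and the step of a 37-fold lower number from compound 1 to compound 2 (1.57 log units; beyond the scatter) is the only measured step, made by putting 4-hydroxyphenyl in place of 2,3,4-trimethoxyphenyl on the carbon with a double bond to nitrogen.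

Compound 3 `COc1cc2ncnc(Nc3ccc(F)c(Cl)c3)c2cc1NC(=O)N/N=C/c1ccc(OC)c(OC)c1OC` has not been measured in this assay. It differs from compound 1 in one place: methyl in place of oxolan-3-yl on an oxygen on an aromatic ring. Among the measured compounds shown here, the one measured step changes a different part of the molecule, the aryl group on the hydrazone carbon, and leaves the ether untouched, so no measured step bears on the change from compound 1 to compound 3. Nothing in the two numbers shown says how this assay responds to the ether, so the expected step of a 1.1-fold lower number from compound 1 to compound 3 (0.05 log units; within the scatter) is none beyond the scatter, with a wide range on either side. The estimate for compound 3 is therefore 30000 nM, between 10000 nM and 100000 nM.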

Compound 3, half-maximal inhibitory concentration: "not active" (no number reported)
Compound 3: no number reported, so the estimate cannot be set against anything.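

In this assay, among these compounds, compound 3 is reported as "not active" with no number, so no step from compound 1 to compound 3 can be read. The compounds shown leave open how far methyl in place of oxolan-3-yl on an oxygen on an aromatic ring shifts the number. No supporting evidence bears on this result.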